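Replacing isobutyl with thiazolyl on the amide nitrogen

The source may report more compounds than this note shows. Statements on the series, on what has been measured and on what is new or still open speak of the compounds shown alone.

Compounds measured so far:
compound 1, `CCN(Cc1cccs1)C(=O)/C=C/c1ccc(C)cc1`, 2 nM
compound 2, `Cc1ccc(OCC(=O)N(Cc2cccs2)CC(C)C)cc1`, 900 nM
compound 3, `CCc1ccc(OCC(=O)N(CC)Cc2cccs2)cc1`, 67 nM

Of the compounds shown here, three have been tested in an assay on HEK293 cells for agonist activity at transient receptor potential cation channel subfamily M member 8 (Homo sapiens), read by fluorescence and calcium flux, with a stated time of 15 min; on this read-out higher numbers stand for an effect only at larger amounts of compound and lower numbers for an effect already at smaller amounts. Compound 1 gives 2 nM, compound 3 gives 67 nM, and compound 2 gives 900 nM. Compound 2 therefore shows the highest number of the three; its gap to compound 3 is beyond the scatter, and its gap to compound 1 is larger still, so among these three compound 2 is the least active.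

Compound 4, `Cc1ccc(OCC(=O)N(Cc2cccs2)c2nccs2)cc1`, has not yet been measured. It differs from compound 2 in one place: 1,3-thiazol-2-yl in place of isobutyl on an amide-type nitrogen. Going by the values given here, no pair of measured compounds differs in a single place, so no directly comparable step is available. Compound 3 carries ethyl rather than isobutyl on the amide nitrogen and shows a lower number than compound 2, but it also differs on the aryl ring, so that comparison does not isolate the nitrogen substituent. An aromatic ring on the amide nitrogen is new to this set. The step from compound 2 to compound 4 is expected to be modest and of uncertain direction, a 1.7-fold higher number from compound 2 to compound 4 (0.22 log units; within the scatter), with a wide range. Compound 4 is estimated to give 1500 nM, between 300 nM and 8000 nM.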

Compound 4, half-maximal effective concentration: 2240 nM
Beside the measured number, compound 4's estimate is 1.5-fold (0.17 log units) below it; low and high end bracket the measured number.
By their numbers in this assay, from the lowest: compound 1; then compound 3; then compound 2; then compound 4.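

In this assay, going by these compounds alone, putting 1,3-thiazol-2-yl in place of isobutyl on the amide-type nitrogen gives a 2.5-fold higher number from compound 2 to compound 4 (0.40 log units; beyond the scatter) and is the first step in this set that isolates this position. It shows that the change has a modest but readable effect in the unfavourable direction: even though the entering group brings a five-membered aromatic ring with two hetero atoms and two hydrogen-bond acceptors, compound 4 still gives a measurable effect, but only at larger amounts than compound 2. Nothing available explains why the number rises, so the step stands as an observation only.

What the compounds shown leave open is whether this rise belongs to the thiazolyl ring itself or to any aromatic ring on this nitrogen, which a phenyl or pyridinyl group in the same place would help to separate. They also leave open whether the same change would have a similar effect on the core of compound 1 or compound 3, and how a longer chain or a chain ending in an amine would compare with isobutyl at this nitrogen.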